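Ring-Closing the Side Chain on Compound 3

The compounds below may be only part of what the source reports. "The series", "measured", "known", "first", "only" and "open" are said of these compounds alone.

Compound 1 `CCCCNC(=O)Nc1cccc2c1CN(C)CC2c1ccccc1` gives 69 mg/kg in a functional assay on the whole organism for inhibition of sodium-dependent dopamine transporter (Mus musculus); a lower number here means that less compound is needed, a higher number that more compound is needed for the effect.
Compound 2 `CCCCOC(=O)Nc1cccc2c1CN(C)CC2c1ccccc1` gives 12 mg/kg in this assay.
Compound 3 `CCCCNCCC(=O)Nc1cccc2c1CN(C)CC2c1ccccc1` gives only a limit of the assay, > 60 mg/kg, in this assay.

All three share one core and differ only in the group on the carbonyl carbon. Putting butoxy in place of butylamino gave a 5.8-fold lower number from compound 1 to compound 2 (0.76 log units; beyond the scatter). Lengthening the chain instead gave a step that the limit leaves unreadable from compound 1 to compound 3, and measured against compound 2 the longer chain gave an at least 5.0-fold higher number from compound 2 to compound 3 (0.69 log units; beyond the scatter). Compound 3 thus stands apart as the one of the three for which the assay gives only a limit (the limit of > 60 mg/kg in this assay, at which 1 of the 3 values shown sits).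

Compound 4 `CN1Cc2c(NC(=O)CN3CCCC3)cccc2C(c2ccccc2)C1` reworks this chain: pyrrolidin-1-yl in place of (butylamino)methyl on a saturated chain carbon bound to a carbonyl carbon. No measured step covers closing an open chain into a ring; the steps shown only tell that the butoxy compound gives the lowest number and that the long open chain sits at the limit. The change is therefore expected to give an at least 1.5-fold lower number from compound 3 to compound 4 (0.17 log units; that floor lies within the scatter), in the direction of a lower number, while a real chance remains that the assay again reports only a limit. Compound 4 is estimated at 40 mg/kg, in a range from 15 mg/kg to 100 mg/kg.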

Compound 4, dose for half-maximal effect: 45 mg/kg
The estimate for compound 4 lay 1.1-fold (0.05 log units) below the measured number; the measured number falls inside the stated range.
By their numbers in this assay, from the lowest: compound 2; then compounds 4 and 1 (each within the scatter of the next).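

Closing the open chain into pyrrolidin-1-yl gives a number that can be read in this assay, but the step is only an at least 1.3-fold lower number from compound 3 to compound 4 (0.12 log units; that floor lies within the scatter), so its true size stays unknown. Set against butylamino on the carbonyl carbon, (pyrrolidin-1-yl)methyl gives a 1.5-fold lower number from compound 1 to compound 4 (0.19 log units; within the scatter), so these two groups cannot be told apart here, while against butoxy it gives a 3.8-fold higher number from compound 2 to compound 4 (0.57 log units; beyond the scatter), which leaves compound 2 with the lowest number of the four. Compound 3 is now the only one of the four held at a limit: the limit of > 60 mg/kg in this assay, at which 1 of the 4 values shown sits.

Compound 4 differs from compound 3 both by having a ring and by lacking the hydrogen-bond donor of the open chain, and the compounds shown cannot separate these two changes. Going by these compounds, it also stays open whether a piperidine ring or a plain dimethylamino group on the same saturated chain carbon would give a similar number, and whether any amine at this position can match the butoxy group of compound 2.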